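From Methyl Ester to Methyl Amide: Expected Solubility

This account rests on a few compounds, and the source may have more. Where it says the series, first, only, none or still open, it means among the compounds named here.

Measured compounds:
compound 1 `COC(=O)c1cc(N)c(Nc2ccc(C#N)cc2)cc1Oc1c(C)cc(/C=C/C#N)cc1C` — 1.3 ug/mL
compound 2 `Cc1cc(CCC#N)cc(C)c1Oc1cc(Nc2ccc(C#N)cc2)c(N)cc1C(F)(F)F` — 0.24 ug/mL

In a physicochemical assay for solubility, with a stated time of 4 h, at pH 7.4 (on this read-out lower numbers stand for lower solubility and higher numbers for higher solubility), compound 1 gives 1.3 ug/mL, the higher of the two numbers recorded. Compound 2 gives 0.24 ug/mL in this assay, and the gap between the two values lies beyond the usual scatter. Among the compounds with values here, compound 1 and compound 2 differ in more than one place, so no single step between measured compounds is available to guide the next move.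

Compound 3 `CNC(=O)c1cc(N)c(Nc2ccc(C#N)cc2)cc1Oc1c(C)cc(/C=C/C#N)cc1C` is reached from compound 1 by a single change: methylamino in place of methoxy on a carbonyl carbon. Within the data shown here, with no measured step of this kind to lean on, the step from compound 1 to compound 3 in this assay is expected to be small, possibly not beyond the scatter, with the direction uncertain, so the estimate stays near the value of compound 1. The estimated step is a 1.2-fold higher number from compound 1 to compound 3 (0.06 log units; within the scatter). Compound 3 is expected to give 1.5 ug/mL in this assay, with a range from 0.4 ug/mL to 5 ug/mL.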

Compound 3, solubility: 1.32 ug/mL
Compound 3: the middle estimate sits 1.1-fold (0.06 log units) above what was measured, and the stated range covers the measured number.
By their numbers in this assay, from the lowest: compound 2; then compounds 1 and 3 (each within the scatter of the next).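

In this assay, methylamino in place of methoxy on a carbonyl carbon gives a 1.0-fold higher number from compound 1 to compound 3 (0.01 log units; within the scatter), so this first readable single change leaves the two compounds indistinguishable on this read-out. The change from methoxycarbonyl to methylcarbamoyl replaces a group counted with 1 hydrogen-bond acceptor and 0 hydrogen-bond donors by one counted with 1 hydrogen-bond donor and 0 hydrogen-bond acceptors, and at this place that exchange produces no step beyond the scatter. No supporting measurement is available to explain this result.

The compounds shown leave open how a dimethylamino group, a morpholine or a free carboxylic acid on the same carbonyl carbon would read. They also leave open whether the same exchange would give a similar step on a different core.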